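The source may hold more compounds than are shown below. What is called first, only, known or untested is meant among the compounds shown, and "the series" means these compounds.

Measured in an ADME assay on microsomes from liver (Homo sapiens) for metabolic stability, with a stated time of 30 min; on this read-out higher numbers stand for a more stable compound and lower numbers for a less stable compound:
- compound 1 `CCCCNC(=O)c1cnc2c(c1)nc(NC(=O)c1cccc(C#N)c1)n2CCCOC`: 95%
- compound 2 `COCCCn1c(NC(=O)c2cccc(C#N)c2)nc2cc(C(=O)N3CCCCC3)ccc21`: 67%

Compound 1 holds the higher of these two numbers. The gap that separates compound 1 from compound 2 lies beyond the usual scatter of repeat measurements. The two differ in more than one place, so their gap belongs to no single change.

Compound 3 `COCCCn1c(NC(=O)c2cccc(C#N)c2)nc2cc(C(=O)N3CCCCC3)cnc21` keeps the core of compound 1 and has not been measured yet. Among the compounds with values here, its one change is piperidin-1-yl in place of butylamino on a carbonyl carbon.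

Compound 2 also carries piperidin-1-yl on a carbonyl carbon, and its core differs from that of compound 1, so it offers only a rough guide. With compound 2 at 67%, a downward step in this assay is expected, estimated as a number 15 percentage points lower from compound 1 to compound 3 (beyond the scatter). For compound 3 the expected value is 80%, with an estimated range from 62% to 95%.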

Compound 3, percent of the compound remaining: 90%
Compound 3: the middle estimate sits 10 percentage points below what was measured, within the range that was stated.
By their numbers in this assay, from the lowest: compound 2; then compounds 3 and 1 (each within the scatter of the next).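

On the core of compound 1, piperidin-1-yl in place of butylamino on a carbonyl carbon gives a number 5 percentage points lower from compound 1 to compound 3 (within the scatter) in this assay, so losing the amide hydrogen and adding the six-membered ring leave no difference that can be separated from the scatter. Compound 2 carries the same piperidin-1-yl group on a different core and gives 67%, while compound 3 gives 90% on the core of compound 1, so the group alone does not fix the read-out at the lower number. Nothing measured here explains this result.

The compounds shown leave open whether a morpholin-4-yl ring or a longer chain such as hexylamino on the same carbonyl carbon would stay as close to compound 1. They also leave open how butylamino would read on the core of compound 2.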